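Swapping the aryl amide cap: from dichloro to methoxy

This account rests on a few compounds, and the source may have more. Where it says the series, first, only, none or still open, it means among the compounds named here.

Measured compounds, all in a functional assay on NCI-H460 cells (Homo sapiens) for inhibition, read by CCK-8 assay, with a stated time of 72 h; on this read-out higher numbers stand for weaker inhibition and lower numbers for stronger inhibition:
compound 1, `Nc1ccccc1NC(=O)c1ccc(CNC(=O)c2n[nH]cc2NC(=O)c2c(F)cccc2Cl)cc1`, 3630 nM
compound 2, `Nc1ccccc1NC(=O)c1ccc(CNC(=O)c2n[nH]cc2NC(=O)c2ccccc2)cc1`, 6320 nM
compound 3, `Nc1ccccc1NC(=O)c1ccc(CNC(=O)c2n[nH]cc2NC(=O)c2c(Cl)cccc2Cl)cc1`, 4190 nM

Compound 3 stands second highest of these three numbers, and the steps leading to it, a 1.2-fold higher number from compound 1 to compound 3 (0.06 log units; within the scatter) and a 1.5-fold lower number from compound 2 to compound 3 (0.18 log units; within the scatter), both lie within the scatter, so the three compounds cannot be told apart here.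

Compound 4, `COc1ccccc1C(=O)Nc1c[nH]nc1C(=O)NCc1ccc(C(=O)Nc2ccccc2N)cc1`, differs from compound 3 in one place: 2-methoxyphenyl in place of 2,6-dichlorophenyl on a carbonyl carbon.

Two measured steps alter the group on that same carbonyl carbon: a 1.7-fold higher number from compound 1 to compound 2 (0.24 log units; within the scatter) and a 1.5-fold lower number from compound 2 to compound 3 (0.18 log units; within the scatter), each within the scatter. On this basis no step beyond the scatter is expected in this assay; the expected change is a 1.2-fold higher number from compound 3 to compound 4 (0.08 log units; within the scatter). Compound 4 is estimated at 5000 nM, with a range from 2000 nM to 12500 nM.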

Compound 4, half-maximal inhibitory concentration: 7350 nM
The estimate for compound 4 lay 1.5-fold (0.17 log units) below the measured number, and the stated range covers the measured number.
By their numbers in this assay, from the lowest: compounds 1, 3, 2 and 4 (each within the scatter of the next, the first and the last beyond it).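

In this assay, the step of a 2.0-fold higher number from compound 1 to compound 4 (0.31 log units; beyond the scatter) passes the scatter, if only modestly, unlike any earlier step at this carbonyl carbon. The steps of a 1.8-fold higher number from compound 3 to compound 4 (0.24 log units; within the scatter) and a 1.2-fold higher number from compound 2 to compound 4 (0.07 log units; within the scatter) stay within it, so 2-methoxyphenyl stands apart only from the 2-chloro-6-fluorophenyl group, and even that gap is small. Nothing available explains this difference.

On these data alone, all four compounds carry a phenyl ring at this place, so it remains open how a saturated ring such as cyclohexyl would read. As far as these compounds go, an amine or a carboxylic acid on the phenyl ring is equally open.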